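The source may hold more compounds than are shown below. What is called first, only, known or untested is meant among the compounds shown, and "the series" means these compounds.

Compound 1 `COc1ccc(-c2cn3ccnc3c(-c3ccc4ncn(C5CCCCC5)c4c3)n2)cc1` and compound 2 `c1cn2cc(-c3ccsc3)nc(-c3ccc4ncn(C5CCCCC5)c4c3)c2n1` share one core. In a functional assay on CCRF-CEM cells (Homo sapiens) for inhibition, read by sulforhodamine B assay, with a stated time of 48 h, tested at 10 uM (on this read-out higher numbers stand for more inhibition at the one concentration tested (going by the name of the read-out) and lower numbers for less inhibition), compound 1 gives 93.3%, and compound 2 gives 29.2%, the lower of the two numbers; the step of a number 64.1 percentage points lower from compound 1 to compound 2 (beyond the scatter) is large. Compound 3 `c1csc(-c2cn3ccnc3c(-c3ccc4ncn(C5CCCCC5)c4c3)n2)c1` is not yet measured. It differs from compound 2 by thiophen-2-yl in place of thiophen-3-yl on an aromatic carbon. Among the compounds with values here, no measured step swaps one thiophenyl for the other, so the only step known, a number 64.1 percentage points lower from compound 1 to compound 2 (beyond the scatter), bears on it indirectly; the expected change is small, within the scatter, in either direction. For compound 3 in this assay the estimate is 35%, with a range from 15% to 60%, an expected step of a number 5.8 percentage points higher from compound 2 to compound 3 (within the scatter).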

Compound 3, a percentage reported as inhibition, at one concentration (the size of the read-out at that concentration, not a potency): 46.4%
Beside the measured number, compound 3's estimate is 11.4 percentage points below it; the measured number falls inside the stated range.
By their numbers in this assay, from the lowest: compound 2; then compound 3; then compound 1.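

In this assay the point of attachment of the thiophene at this aromatic carbon matters even though the atoms stay the same, the step being a number 17.2 percentage points higher from compound 2 to compound 3 (beyond the scatter) for thiophen-2-yl in place of thiophen-3-yl. The better of the two thiophenes still leaves a large gap to 4-methoxyphenyl, the step being a number 46.9 percentage points lower from compound 1 to compound 3 (beyond the scatter) at this position. Nothing available here explains either step.

Open, as far as these compounds go, is whether a plain phenyl or a 4-hydroxyphenyl at this carbon would stand nearer to compound 1 or to compound 3.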